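Removing the Hydroxy Group from Compound 3

The source may report more compounds than this note shows. Statements on the series, on what has been measured and on what is new or still open speak of the compounds shown alone.

Three hydrazones built on one shared core have been measured. In a functional assay on MCF7 cells (Homo sapiens) for antiproliferative activity, read by MTT assay, with a stated time of 24 h (on this read-out lower numbers stand for stronger inhibition and higher numbers for weaker inhibition), compound 1 `CC1=C/C(=N\NC(=O)c2ccncc2)c2c(O)cccc2C1=O` gives 6200 nM, compound 2 `CC1=C/C(=N\NC(=O)c2cccnc2)c2c(O)cccc2C1=O` gives 2700 nM, and compound 3 `CC1=C/C(=N\NC(=O)c2ccccc2O)c2c(O)cccc2C1=O` gives 5300 nM. Compound 3 thus holds the second highest of the three numbers: its nearest neighbour is compound 1, with a 1.2-fold lower number from compound 1 to compound 3 (0.07 log units; within the scatter), and its furthest is compound 2, with a 2.0-fold higher number from compound 2 to compound 3 (0.29 log units; within the scatter). Both of those steps lie within the scatter; only a 2.3-fold lower number from compound 1 to compound 2 (0.36 log units; beyond the scatter) reaches beyond it.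

Compound 4 `CC1=C/C(=N\NC(=O)c2ccccc2)c2c(O)cccc2C1=O` arises from compound 3 through (hydrogen in place of hydroxy on an aromatic carbon). For the measured compounds named here, none of the measured steps removes a hydroxy group; all three exchange one whole aromatic group for another, and the two that involve compound 3 stayed within the scatter. With nothing in the data pointing to a shift, compound 4 is expected to sit close to compound 3, and a 1.1-fold lower number from compound 3 to compound 4 (0.03 log units; within the scatter) is expected to remain within the scatter. In this assay compound 4 is therefore estimated at 5000 nM, with a range from 2500 nM to 10000 nM.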

Compound 4, half-maximal inhibitory concentration: 2800 nM
Compound 4: the middle estimate sits 1.8-fold (0.25 log units) above what was measured, and the stated range covers the measured number.
By their numbers in this assay, from the lowest: compounds 2, 4, 3 and 1 (each within the scatter of the next, the first and the last beyond it).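

In this assay, taking the hydroxy group off the 2-hydroxyphenyl ring gives a 1.9-fold lower number from compound 3 to compound 4 (0.28 log units; within the scatter) and so stays inside the scatter: at this carbon, ortho to a large group, the hydroxy group is not needed to keep the number where it stands. The plain phenyl group cannot be told apart from pyridin-3-yl, with a 1.0-fold higher number from compound 2 to compound 4 (0.02 log units; within the scatter) on that exchange, but it does separate from pyridin-4-yl, with a 2.2-fold lower number from compound 1 to compound 4 (0.35 log units; beyond the scatter) as a modest step that compound 3 does not achieve against compound 1. Nothing on hand explains any of these steps.

As far as these compounds go, whether an amine, a methoxy group or a carboxylic acid at this carbon would leave the number in the same place remains open. So does whether the hydroxy group behaves alike on another carbon of the ring.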